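The compounds below may be only part of what the source reports. "The series", "measured", "known", "first", "only" and "open" are said of these compounds alone.

In an assay on microsomes from liver for inhibition of sterol O-acyltransferase 1 (Rattus norvegicus) (on this read-out higher numbers stand for weaker inhibition and lower numbers for stronger inhibition), the three measured compounds gave the following numbers:

Compound 1 `CCCCCCCCCCCCn1nnc(C(NC(=O)c2ccc(F)cc2F)c2ccccc2)n1`: 490 nM
Compound 2 `CCCCCCCCCCCCn1nnc(C(NC(=O)c2ccc(Cl)cc2)c2ccccc2)n1`: 440 nM
Compound 3 `CCCCCCCCCCCCn1nnc(C(NC(=O)c2ccccc2[N+](=O)[O-])c2ccccc2)n1`: 240 nM

Compound 3 carries the lowest of the three numbers. Its separation from compound 2 is a 1.8-fold lower number from compound 2 to compound 3 (0.26 log units; within the scatter), which does not rise above the scatter, whereas its separation from compound 1 is a 2.0-fold lower number from compound 1 to compound 3 (0.31 log units; beyond the scatter), a modest but genuine step.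

Compound 4 `CCCCCCCCCCCCn1nnc(C(NC(=O)c2ccnc(SC)c2)c2ccccc2)n1` is the next variation on the same amide. Its difference from compound 3 is a group of 8 heavy atoms (6 carbon, 1 nitrogen, 1 sulfur; one six-membered aromatic ring with 1 hetero atom) in place of a group of 9 heavy atoms (6 carbon, 1 nitrogen, 2 oxygen; one six-membered aromatic ring of carbon only), on a carbonyl carbon. All three measured steps concern exactly this position, an aryl group on the carbonyl carbon exchanged for another: a 1.1-fold lower number from compound 1 to compound 2 (0.05 log units; within the scatter), a 2.0-fold lower number from compound 1 to compound 3 (0.31 log units; beyond the scatter) and a 1.8-fold lower number from compound 2 to compound 3 (0.26 log units; within the scatter). None of them moved the number by more than a modest amount, and two of them stayed inside the scatter. The expectation for compound 4 is therefore a small step in this assay, most likely towards a somewhat higher number, since compound 3 already sits at the low end of the three, but not clearly beyond the scatter.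

Compound 4 is thus estimated at 350 nM, with a likely range from 150 nM to 800 nM, which corresponds to an expected step of a 1.5-fold higher number from compound 3 to compound 4 (0.16 log units; within the scatter).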

Compound 4, half-maximal inhibitory concentration: 80 nM
Estimate against measurement, compound 4: 4.4-fold (0.64 log units) above, and the stated range ends above it.
By their numbers in this assay, from the lowest: compound 4; then compounds 3, 2 and 1 (each within the scatter of the next, the first and the last beyond it).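

In this assay, this position on a carbonyl carbon turns out to have more room for change than the earlier aryl exchanges showed, for those stayed inside the scatter or only just beyond it. The group with a six-membered aromatic ring with 1 hetero atom gives a 3.0-fold lower number from compound 3 to compound 4 (0.48 log units; beyond the scatter), and the steps from the two other compounds are larger still: a 5.5-fold lower number from compound 2 to compound 4 (0.74 log units; beyond the scatter) and a 6.1-fold lower number from compound 1 to compound 4 (0.79 log units; beyond the scatter). Compound 4 is therefore the strongest inhibitor of the four on this read-out, and no measurement shown here bears on the reason for its gain.

On these data alone, compound 4 brings in the ring hetero atom and the sulfur together, so it remains open which of them carries the step; the same ring with an amine or a methoxy group in place of the sulfur-bearing group would separate the two. As far as these compounds go, the long chain on the shared core is the same in all four compounds, so whether the gain holds with a shorter chain also remains open.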